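The source may report more compounds than this note shows. Statements on the series, on what has been measured and on what is new or still open speak of the compounds shown alone.

The measured compounds in a functional assay on MCF7 cells (Homo sapiens) for antiproliferative activity, read by MTT assay, with a stated time of 72 h (a lower number here means a stronger inhibitor, a higher number a weaker inhibitor), are these. Compound 1, `O=c1[nH]c(=O)n(CCC(CO)CO)cc1-c1ccco1`, gives < 10 nM, a limit of the assay rather than a number. Compound 2, `O=c1[nH]c(=O)n(CCC(CO)CO)cc1-c1cccs1`, gives 6000 nM. Compound 3, `CCCCCc1ccc(C#Cc2cn(CCC(COC(C)=O)COC(C)=O)c(=O)n(C(=O)c3ccccc3)c2=O)cc1`, gives 100 nM.

Of the two numbers shown, compound 3 has the lower one; compound 2 has a clearly higher number, and compound 1 sits at the limit, as noted in the limit of < 10 nM in this assay, at which 1 of the 3 values shown sits. For the measured compounds named here, the one measured step, an at least 600-fold higher number from compound 1 to compound 2 (2.77 log units; beyond the scatter), is large, but it concerns a swap of one aromatic ring for another on an aromatic carbon of the core shared by compound 1 and compound 2, which is a different part of the structure from the one changed here.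

Compound 4, `CCCCCC#Cc1cn(CCC(COC(C)=O)COC(C)=O)c(=O)n(C(=O)c2ccccc2)c1=O`, differs from compound 3 in this way: pentyl in place of 4-pentylphenyl on a triple-bonded carbon. Going by the values given here, no measured step touches this part of the molecule, so the direction and size of the step can only be guessed from the loss of the aromatic ring. Since removing the ring takes away a sizable piece of the molecule, compound 4 is expected to give a higher number, around 800 nM, within 150 nM to 5000 nM, which would mean a step of an 8.0-fold higher number from compound 3 to compound 4 (0.90 log units; beyond the scatter).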

Compound 4, half-maximal inhibitory concentration: 62200 nM
Compound 4: middle estimate off by 78-fold (1.89 log units), on the low side, and the stated range ends below it.
By their numbers in this assay, from the lowest: compound 3; then compound 2; then compound 4. At a limit, below all of these: compound 1.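

In this assay, for the compounds shown here, replacing the group on the triple-bonded carbon gives a 620-fold higher number from compound 3 to compound 4 (2.79 log units; beyond the scatter), the first measured step at this position, and it shows that activity here depends strongly on which group this carbon carries. The pentyl that enters does not stand in for the 4-pentylphenyl that leaves, even though the rest of the molecule is unchanged, so a pentyl chain on this carbon is not enough to keep the number of compound 3. The change removes the six-membered aromatic ring and also drops from 11 heavy atoms to 5, so this single step cannot say whether the ring itself or the overall size of the group matters more, and nothing measured here explains the size of the step.

The compounds shown leave open whether a longer chain such as decyl, with no ring, would bring the number back towards that of compound 3, or whether a plain phenyl would do so without the pentyl tail. They also leave open how an amine or a carboxylic acid at the end of the group on the triple-bonded carbon would behave.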